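Cutting the Benzyloxy Group Back to Methoxy

The compounds below may be only part of what the source reports. "The series", "measured", "known", "first", "only" and "open" are said of these compounds alone.

For the measured compounds named here, in a functional assay on RAW264.7 cells (Mus musculus) for inhibition, read by Griess assay, with stated times of 1 h and 24 h (on this read-out higher numbers stand for weaker inhibition and lower numbers for stronger inhibition), compound 2 `O=C1CC(c2ccccc2OCc2ccccc2)Oc2ccccc21` gives 18900 nM as the lower of the two numbers so far, against compound 1 `CCCOc1ccccc1C1CC(=O)c2ccccc2O1` at 46000 nM in the same test. Compound 3 `COc1ccccc1C1CC(=O)c2ccccc2O1` has hydrogen in place of phenyl on a saturated chain carbon bound to an oxygen on an aromatic ring, so benzyloxy becomes methoxy. Going by the values given here, the only measured step bearing on this is a 2.4-fold lower number from compound 1 to compound 2 (0.39 log units; beyond the scatter) with phenyl in place of ethyl. Losing the phenyl is expected to run the other way at similar modest size, an estimated 2.6-fold higher number from compound 2 to compound 3 (0.42 log units; beyond the scatter) overall. In this assay compound 3 is expected at 50000 nM (estimated range 22000 nM to 110000 nM).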

Compound 3, half-maximal inhibitory concentration: 47300 nM
Compound 3: middle estimate off by 1.1-fold (0.02 log units), on the high side; the measured number falls inside the stated range.
By their numbers in this assay, from the lowest: compound 2; then compounds 1 and 3 (each within the scatter of the next).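

Cutting benzyloxy back to methoxy gives a 2.5-fold higher number from compound 2 to compound 3 (0.40 log units; beyond the scatter) and so undoes the stronger inhibition of the benzyloxy compound. Methoxy and propoxy, by contrast, do not separate, with a 1.0-fold higher number from compound 1 to compound 3 (0.01 log units; within the scatter) as the step between them, so among these three groups only benzyloxy stands apart. No supporting data explain why the phenyl makes this difference.

As far as these compounds go, whether a longer chain ending in a phenyl would keep the stronger inhibition remains open. So does the effect of an amine or a carboxylic acid at this place.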